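Methyl for hydrogen on the ring of compound 2

The compounds below may be only part of what the source reports. "The series", "measured", "known", "first", "only" and "open" are said of these compounds alone.

compound 1 `O=c1c(C(=S)Nc2ccccc2)coc2ccccc12`: 58%
compound 2 `O=c1c(C2N=C(c3ccccc3)SS2)coc2ccccc12`: 11%
compound 3 `O=c1c(C2N=C(c3ccccc3)SS2)coc2cc(Cl)ccc12`: 91%

In a functional assay on OVCAR-3 cells (Homo sapiens) for inhibition, read by sulforhodamine B assay, with a stated time of 48 h, tested at 100 uM (a lower number here means less inhibition of growth, a higher number more inhibition of growth at the concentration tested), compound 2 stands lowest of the three measured numbers, with compound 1 a good way above it and compound 3 furthest above it. Compound 4 `Cc1ccc2occ(C3N=C(c4ccccc4)SS3)c(=O)c2c1` differs from compound 2 in one place: methyl in place of hydrogen on an aromatic carbon. A single measured step bears on this change, the step of a number 80 percentage points higher from compound 2 to compound 3 (beyond the scatter), in which a chloro group stands where compound 2 carries a hydrogen. Going by the values given here, no measured step shows what a methyl does on this core, so the direction is taken from that one step and the size is held back. An increase beyond the scatter is expected for compound 4, and it is estimated at 50% with a range from 15% to 85%. That estimate means an expected step of a number 39 percentage points higher from compound 2 to compound 4 (beyond the scatter).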

Compound 4, percent growth inhibition at one concentration: 54%
Beside the measured number, compound 4's estimate is 4 percentage points below it; the measured number falls inside the stated range.
By their numbers in this assay, from the lowest: compound 2; then compounds 4 and 1 (each within the scatter of the next); then compound 3.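

In this assay, methyl in place of hydrogen on this aromatic carbon gives a number 43 percentage points higher from compound 2 to compound 4 (beyond the scatter), the first measured effect of a methyl on the shared core. Read with a number 80 percentage points higher from compound 2 to compound 3 (beyond the scatter), it shows that a large rise from compound 2 is not confined to chloro, since a carbon substituent on the same aromatic ring also produces one.

On these data alone, whether an amine or a longer chain such as ethyl on this aromatic carbon would raise the number as well remains open. No measurement at hand explains this rise.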